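Ketone oxazole series: swapping the aryl on the oxazole

The compounds below may be only part of what the source reports. "The series", "measured", "known", "first", "only" and "open" are said of these compounds alone.

In an assay (Rattus norvegicus) for inhibition of Fatty-acid amide hydrolase 1 (Homo sapiens) (on this read-out lower numbers stand for stronger inhibition and higher numbers for weaker inhibition), compound 2 `Nc1ccc(-c2cnc(C(=O)CCCCCCc3ccccc3)o2)cc1` gives 90 nM, the highest of the three numbers in hand. Compound 1 `COC(=O)c1ccccc1-c1cnc(C(=O)CCCCCCc2ccccc2)o1` gives 60 nM, which lies within the scatter of compound 2, so no order between the two can be claimed. Compound 3 `COC(=O)c1ccc(-c2cnc(C(=O)CCCCCCc3ccccc3)o2)nc1` gives 3.5 nM, a gap to compound 2 that stands well beyond the scatter. Compound 4 `NS(=O)(=O)c1ccc(-c2cnc(C(=O)CCCCCCc3ccccc3)o2)s1` has not been measured; it differs from compound 2 by 5-sulfamoylthiophen-2-yl in place of 4-aminophenyl on an aromatic carbon. Going by the values given here, no step between measured compounds isolates this change, and compound 3 shows that another aryl on the same position can sit far lower. Compound 4 is therefore expected to move toward stronger inhibition, a step of a 4.5-fold lower number from compound 2 to compound 4 (0.65 log units; beyond the scatter), with the estimate for compound 4 at 20 nM, ranging from 4 nM to 100 nM.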

Compound 4, inhibition constant: 3 nM
The estimate for compound 4 lay 6.7-fold (0.82 log units) above the measured number; the measured number lies below the stated range.
By their numbers in this assay, from the lowest: compounds 4 and 3 (each within the scatter of the next); then compounds 1 and 2 (each within the scatter of the next).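

In this assay, going by these compounds alone, the change to 5-sulfamoylthiophen-2-yl on the aromatic carbon next to the ring oxygen gives a 30-fold lower number from compound 2 to compound 4 (1.48 log units; beyond the scatter) and is the only step yet read at this position. Compound 4 and compound 3 lie within the scatter of each other, so two different aromatic groups here share the low end of the series. Nothing at hand explains the size of this step. The compounds shown leave open whether the sulfamoyl group or its ring carries the step. They also leave open whether a carboxylic acid in place of the sulfamoyl group would hold the number.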